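The compounds below may be only part of what the source reports. "The series", "measured", "known", "first", "only" and "open" are said of these compounds alone.

Compound 1 `Cc1nn(-c2ccccc2)c2nc(-c3ccccc3)c(C#N)c(-c3ccccc3O)c12`: > 23000 nM
Compound 2 `Cc1nn(-c2ccccc2)c2nc(-c3ccc4ccccc4c3)c(C#N)c(-c3ccccc3O)c12`: > 20000 nM

In an ADME assay on BJ cells (Homo sapiens) for cytotoxicity, with a stated time of 72 h (a higher number here means that more compound is needed for the effect, a lower number that less compound is needed), compound 2 gives > 20000 nM, which is a limit of the assay and not a number. Compound 1 gives > 23000 nM, and this too is a limit. Neither value is an exact measurement, so compound 2 can be placed only by its limit.

The next compound, compound 3 `Cc1nn(-c2ccccc2)c2nc(-c3ccc(F)cc3)c(C#N)c(-c3ccccc3O)c12`, has 4-fluorophenyl in place of naphthalen-2-yl on an aromatic carbon. This carbon lies next to the ring nitrogen and ortho to a cyano group.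

Among the compounds with values here, only one measured step bears on this change, and it concerns the same carbon: a step that the two limits leave unreadable from compound 1 to compound 2. That step has no readable size, so it gives no sign of any effect from the group at this carbon. A step beyond the usual scatter is therefore not expected in this assay, and no direction can be favoured. Compound 3 will probably be reported as a limit as well.

The estimated change is a step that the limit leaves unreadable from compound 2 to compound 3. Compound 3 is expected at about 22000 nM, with an estimated range of 10000 nM to 40000 nM.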

Compound 3, half-maximal effective concentration: > 20000 nM
Compound 3 was reported as a limit; the forecaster's own chance of this, stated with the estimate: 80%; the middle value lies beyond the limit too.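

In this assay compound 3 gives > 20000 nM, which is a limit of the assay and not a number. Within the data shown here, compound 1, compound 2 and compound 3 all stand at limits, so no step among them can be read. The compounds shown leave open how much of each is needed for the effect, and whether the group on this aromatic carbon changes that amount.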